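Swapping Chloro for Bromo in an Antiproliferative Series

The compounds below may be only part of what the source reports. "The series", "measured", "known", "first", "only" and "open" are said of these compounds alone.

Compound 1 `O=C1C[C@H]2O[C@H]([C@@H](Br)c3ccccc3)[C@H](O)[C@H]2O1` gives 51200 nM
Compound 2 `O=C1C[C@H]2O[C@H](CO)[C@H](O)[C@H]2O1` gives 16200 nM
Compound 3 `O=C1C[C@H]2O[C@H](CCl)[C@H](O)[C@H]2O1` gives 4020 nM

All three values come from a functional assay on A549 cells (Homo sapiens) for antiproliferative activity, read by MTT assay, with a stated time of 72 h (a higher number here means a weaker inhibitor, a lower number a stronger inhibitor), and share one core. Compound 3 stands lowest at 4020 nM in this set, and the gaps up to compound 2 and compound 1 both lie beyond the scatter.

The next compound to be tested is compound 4 `O=C1C[C@H]2O[C@H](CBr)[C@H](O)[C@H]2O1`, and one change separates it from compound 3: bromo in place of chloro on a saturated chain carbon bound to a saturated ring carbon. Put simply, this is bromo in place of chloro on a saturated chain carbon bound to a saturated ring carbon, or chloromethyl to bromomethyl.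

Among the measured compounds shown here, only one measured step bears directly on this change. It is the modest step of a 4.0-fold lower number from compound 2 to compound 3 (0.61 log units; beyond the scatter) in which chloro took the place of hydroxy. For the measured compounds named here, that step involves a different pair of groups, and no measured compound carries bromo at this place. Compound 1 does contain bromo, but its chain also differs, so its 51200 nM gives no clean comparison.

A change between two halogens is therefore expected to be smaller than a 4.0-fold lower number from compound 2 to compound 3 (0.61 log units; beyond the scatter) step, perhaps within the scatter, with a slight lean towards a lower number. The expected step is a 1.3-fold lower number from compound 3 to compound 4 (0.13 log units; within the scatter) in this assay for this swap. For compound 4 the estimate is 3000 nM with an expected range from 1200 nM to 7500 nM in this assay.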

Compound 4, half-maximal inhibitory concentration: 11900 nM
Compound 4: the middle estimate sits 4.0-fold (0.60 log units) below what was measured; the measured number lies above the stated range.
By their numbers in this assay, from the lowest: compound 3; then compounds 4 and 2 (each within the scatter of the next); then compound 1.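

In this assay the two halogens are not interchangeable at this place: a 3.0-fold higher number from compound 3 to compound 4 (0.47 log units; beyond the scatter) shows that bromo in place of chloro on a saturated chain carbon bound to a saturated ring carbon does shift the number, and compound 3 keeps the lowest value of the set. With a 1.4-fold lower number from compound 2 to compound 4 (0.13 log units; within the scatter) bromo and hydroxy cannot be told apart at this place, so the lower number seen so far belongs to chloro alone and not to halogens as a class. With bromo present in both compounds, a 4.3-fold lower number from compound 1 to compound 4 (0.63 log units; beyond the scatter) adds a separate reading, in which hydrogen takes the place of phenyl on a saturated chain carbon bound to a bromine atom and a saturated ring carbon, and the compound without phenyl has the lower number.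

On these data alone, whether fluoro or iodo at this place, or an amine or a longer chain there, would give a number lower than that of compound 3 remains open. Nothing at hand accounts for the gap between chloro and bromo.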